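Aryl Fluoro to Trifluoromethyl on the Ethyl Chain Member

A few compounds are considered here, and "the series" means these few. Any claim that something is new, unique, unknown or untested is made for them only; others in the source may bear on it.

Compound 2 `CCC(C(=O)N1CCN(c2cccc(F)c2)CC1)N1C(=O)CCC1=O` is the weakest of the three measured compounds: in a functional assay on the whole organism (strain Swiss) with Mus musculus as the target, in the maximal electroshock model, with a stated time of 0.25 h, at a dose of 100 mg/kg by the intraperitoneal route (on this read-out lower numbers stand for a weaker effect and higher numbers for a stronger effect at the one dose given), compound 2 gives 0%, the lowest number shown, with compound 3 `CC(C(=O)N1CCN(c2cccc(F)c2)CC1)N1C(=O)CCC1=O` at 75% as its nearest neighbour and compound 1 `COCC(C(=O)N1CCN(c2cccc(C(F)(F)F)c2)CC1)N1C(=O)CCC1=O` at 100% furthest away. For the measured compounds named here, the one measured single-point step, a number 75 percentage points higher from compound 2 to compound 3 (beyond the scatter), concerns the saturated chain and not the aromatic ring.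

Compound 4 `CCC(C(=O)N1CCN(c2cccc(C(F)(F)F)c2)CC1)N1C(=O)CCC1=O` differs from compound 2 at the ring: trifluoromethyl in place of fluoro on an aromatic carbon. Going by the values given here, no measured pair isolates this change. Compound 1 carries the same trifluoromethyl and gives the highest number, but it also carries a different chain, so its value cannot be read as the effect of the ring change alone. The estimate for compound 4 therefore rests on little: a rise from compound 2 is expected, a number 40 percentage points higher from compound 2 to compound 4 (beyond the scatter), with wide uncertainty. Compound 4 is estimated at 40%, in the range 0% to 100%.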

Compound 4, a percentage reported as activity, at one dose (the size of the read-out at that dose, not a potency): 75%
Compound 4: middle estimate off by 35 percentage points, on the low side, within the range that was stated.
By their numbers in this assay, from the lowest: compound 2; then compounds 3 and 4 (each within the scatter of the next); then compound 1.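

In this assay, the aromatic carbon carrying fluoro in compound 2 proves to be a sensitive position: with the chain unchanged, trifluoromethyl in place of fluoro gives a number 75 percentage points higher from compound 2 to compound 4 (beyond the scatter), the first single-place step measured on the ring. The chain still counts when trifluoromethyl is on the ring, as methyl in place of methoxy on the saturated chain carbon gives a number 25 percentage points lower from compound 1 to compound 4 (beyond the scatter). Nothing at hand gives a reason for either step.

From the compounds shown here alone, the ring change is read on one chain only, so its size with the shorter chain of compound 3 or the methoxy-bearing chain of compound 1 remains open. Also open, going by these compounds, is how a chloro group or a nitrile at the same aromatic carbon, or an amine or a longer chain at the saturated chain carbon, would compare.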